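The source may hold more compounds than are shown below. What is called first, only, known or untested is meant among the compounds shown, and "the series" means these compounds.

Measured compounds in a functional assay on HEK293 cells for agonist activity at Free fatty acid receptor 1 (Homo sapiens), read by fluorescence and calcium flux, with a stated time of 10 min; on this read-out higher numbers stand for larger maximal responses and lower numbers for smaller maximal responses:
- compound 1, `COc1ccc2c(c1)OC(COc1ccc(CCC(=O)O)c(F)c1)CC2`: 58%
- compound 2, `O=C(O)CCc1ccc(NCC2COc3ccc(Cl)cc3O2)cc1F`: 69%
- compound 3, `CC#CC(CC(=O)O)c1ccc(OCC2COc3ccc(Cl)cc3O2)cc1`: 104%

Compound 3 gives the largest maximal response of the three; its distance to compound 2 and its distance to compound 1 are both beyond the scatter, so it stands alone at the top of this set.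

Compound 4, `CCOC(CC(=O)O)c1ccc(OCC2COc3ccc(Cl)cc3O2)cc1`, has not yet been measured. It differs from compound 3 in one place: ethoxy in place of prop-1-yn-1-yl on a saturated chain carbon bound to an aromatic carbon and a saturated chain carbon. Going by the values given here, no measured pair in the set shares this change, so the expectation rests on the shared core and acid chain alone. A modest loss is expected, not certainly beyond the scatter, with the step from compound 3 to compound 4 estimated at a number 14 percentage points lower from compound 3 to compound 4 (beyond the scatter). Compound 4 is estimated at 90%, within a range from 70% to 110%.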

Compound 4, largest response reached (Emax), in percent of the reference or control that the assay uses: 46%
Beside the measured number, compound 4's estimate is 44 percentage points above it; measured number below the stated range.
By their numbers in this assay, from the lowest: compound 4; then compound 1; then compound 2; then compound 3.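

In this assay, the saturated chain carbon bound to an aromatic carbon and a saturated chain carbon proves sensitive to its substituent: ethoxy in place of prop-1-yn-1-yl gives a number 58 percentage points lower from compound 3 to compound 4 (beyond the scatter). Both groups have 3 heavy atoms, so the maximal response changes sharply with no change in that count, the rest of the structure staying the same. Nothing at hand accounts for the loss. Open, on these data alone, is how a propyl, a cyclopropyl or a methoxy group on this carbon would read out, and so whether the triple bond or the oxygen decides the step.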